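This account rests on a few compounds, and the source may have more. Where it says the series, first, only, none or still open, it means among the compounds named here.

Of the compounds shown here, three with a shared core have been measured so far. Compound 1 `CC(C)(C)n1nc2c(c1-c1ccccc1)CCNCC2` gives 30 nM in an assay on HEK293 cells for displacement of a labelled ligand from 5-hydroxytryptamine receptor 7 (Rattus norvegicus), read by radioligand binding; a higher number here means a weaker inhibitor, a lower number a stronger inhibitor. In this assay, within the data shown here, compound 2 `c1ccc(-c2c3c(nn2C2CC2)CCNCC3)cc1` gives 20 nM, and the single one-place step between measured compounds runs a 1.5-fold lower number from compound 1 to compound 2 (0.18 log units; within the scatter). Compound 3 `Cc1ccc(-c2c3c(nn2C(C)C)CCNCC3)cc1` gives 6 nM in this assay, the lowest of the three numbers; compound 2 is its nearest neighbour and compound 1 its furthest, and both gaps lie beyond the scatter. Compound 2 and compound 3 differ in more than one place, so their gap cannot be tied to a single change.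

Compound 4 `CC(C)n1nc2c(c1-c1ccc(Cl)cc1)CCNCC2` differs from compound 3 in one respect: chloro in place of methyl on an aromatic carbon. Among the measured compounds shown here, no measured step bears on this change. For the measured compounds named here, the only step known, a 1.5-fold lower number from compound 1 to compound 2 (0.18 log units; within the scatter), concerns the group on the aromatic nitrogen, not the six-membered ring, and it stayed within the scatter. With nothing to point either way, compound 4 is expected to stay close to compound 3, the expected step being no change at the digits printed from compound 3 to compound 4 (within the scatter). The estimate for compound 4 in this assay is 6 nM, with a range from 2 nM to 18 nM.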

Compound 4, inhibition constant: 9 nM
Compound 4: middle estimate off by 1.5-fold (0.18 log units), on the low side; low and high end bracket the measured number.
By their numbers in this assay, from the lowest: compounds 3 and 4 (each within the scatter of the next); then compounds 2 and 1 (each within the scatter of the next).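

Among these compounds, the step from methyl to chloro gives the first reading at this position, on an aromatic carbon of the six-membered aromatic ring of carbon only, para to a large group: in this assay there is a 1.5-fold higher number from compound 3 to compound 4 (0.18 log units; within the scatter). The earlier one-place step concerned only the group on the aromatic nitrogen, whereas this one shows that the two groups, each of one heavy atom, cannot be told apart at this aromatic carbon. Nothing available explains why they read alike.

The compounds shown leave open how a methoxy group, an amine or a carboxylic acid would read at this position. They also leave open whether chloro and methyl would still read alike with cyclopropyl or tert-butyl on the aromatic nitrogen.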